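A few compounds are considered here, and "the series" means these few. Any claim that something is new, unique, unknown or untested is made for them only; others in the source may bear on it.

Compound 1, `COc1ccc(Nc2nc(/C=C/c3cc(OC)c(OC)c(OC)c3)nc3ccsc23)cc1`: > 50000 nM
Compound 2, `COc1cc(/C=C/c2nc(Nc3ccc(C(F)(F)F)cc3)c3sccc3n2)cc(OC)c1OC`: > 50000 nM
Compound 3, `COc1ccc(CNc2nc(/C=C/c3cc(OC)c(OC)c(OC)c3)nc3ccsc23)cc1`: > 50000 nM

In an ADME assay on RAW264.7 cells (Mus musculus) for cytotoxicity, read by MTT assay (on this read-out higher numbers stand for weaker inhibition and lower numbers for stronger inhibition), none of the three compounds gives a number. The value of compound 1 is a limit of the assay. The value of compound 2 is likewise a limit. The value of compound 3 is also a limit, so compound 3 stands, like its two neighbours, at the limit of > 50000 nM in this assay, at which 3 of the 3 values shown sit. The steps between them cannot be read: a step that the two limits leave unreadable from compound 1 to compound 2, a step that the two limits leave unreadable from compound 1 to compound 3 and a step that the two limits leave unreadable from compound 2 to compound 3 are all hidden by the limits on both sides.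

Compound 4, `COc1cc(/C=C/c2nc(NCc3ccncc3)c3sccc3n2)cc(OC)c1OC`, differs from compound 3 in one place: pyridin-4-yl in place of 4-methoxyphenyl on a saturated chain carbon bound to a nitrogen on an aromatic ring. Among the measured compounds shown here, no measured step bears on this change directly, and the three steps that are available give no readable size in this assay. Whatever the change at the benzylic carbon does, the expectation is that compound 4 again reaches the limit, so that a number no higher from compound 3 to compound 4 (the limit leaves the size open) is expected to be unreadable. On that basis compound 4 is estimated at 50000 nM, within a range from 20000 nM to 100000 nM, with the most likely outcome being that the assay once more reports only a limit.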

Compound 4, half-maximal inhibitory concentration: > 50000 nM
Compound 4: no number, only a limit; the forecaster's own chance of this, stated with the estimate: 85%; the middle value sits exactly at the limit.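

In this assay compound 4 gives > 50000 nM, which is a limit of the assay and not a number, so the steps to compound 4 from compound 1, compound 2 and compound 3 cannot be read. The compounds shown leave open whether any of these changes alters the value at all, as all four stand at one limit: the limit of > 50000 nM in this assay, at which 4 of the 4 values shown sit.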